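The source may hold more compounds than are shown below. What is called first, only, known or untested is meant among the compounds shown, and "the series" means these compounds.

Working notes on the amide series.

Compound 3 `Nc1ncnc2c1ncn2C1O[C@H](C(=O)NC2CCCCCC2)[C@@H](O)[C@H]1O` gives 22 nM in an assay on cell membranes for binding affinity to 2-oxoglutarate receptor 1 (Rattus norvegicus), read by radioligand binding; on this read-out lower numbers stand for stronger inhibition and higher numbers for weaker inhibition. Compound 1 `CCCCCCCNC(=O)[C@H]1OC(n2cnc3c(N)ncnc32)[C@H](O)[C@@H]1O` gives 20 nM in this assay, and compound 2 `CCCCCCCCNC(=O)[C@H]1OC(n2cnc3c(N)ncnc32)[C@H](O)[C@@H]1O` gives 21 nM; the three numbers lie within the scatter of one another, so compound 3 is not set apart from either neighbour, as a 1.1-fold higher number from compound 1 to compound 3 (0.04 log units; within the scatter) and a 1.0-fold higher number from compound 2 to compound 3 (0.02 log units; within the scatter) show, and a 1.1-fold higher number from compound 1 to compound 2 (0.02 log units; within the scatter) likewise.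

Compound 4 `CC(C)CONC(=O)[C@H]1OC(n2cnc3c(N)ncnc32)[C@H](O)[C@@H]1O` is not yet measured. It differs from compound 3 by isobutoxy in place of cycloheptyl on an amide-type nitrogen. The measured steps all exchange one hydrocarbon group on the amide-type nitrogen for another and stay within the scatter; none brings an oxygen into the group on that nitrogen, so they bear on the new step only loosely. Given that the hydrocarbon exchanges to compound 3 cost nothing, no large shift is expected, but the entering isobutoxy is untested here and a modest move toward a higher number is expected, a 2.7-fold higher number from compound 3 to compound 4 (0.44 log units; beyond the scatter). Compound 4 is estimated at 60 nM, with a range from 15 nM to 300 nM.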

Compound 4, inhibition constant: 20 nM
For compound 4 the middle estimate is 3.0-fold (0.48 log units) above the measured one; measured number inside the range.
By their numbers in this assay, from the lowest: compounds 1, 4, 2 and 3 (each within the scatter of the next).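

The group on the amide-type nitrogen now carries an oxygen, and in this assay isobutoxy is not set apart from cycloheptyl (a 1.1-fold lower number from compound 3 to compound 4 (0.04 log units; within the scatter)), from octyl (a 1.1-fold lower number from compound 2 to compound 4 (0.02 log units; within the scatter)) or from heptyl (no change at the digits printed from compound 1 to compound 4 (within the scatter)). This position therefore holds a seven-membered carbon ring, two straight chains and a branched group joined through oxygen, with no step among these four compounds beyond the scatter. No supporting data bear on why these groups read alike.

Going by these compounds, what the oxygen itself contributes stays open, as reading it directly would take isopentyl on the same nitrogen, the all-carbon counterpart of isobutoxy. Also open, on these data alone, is whether this flat picture extends to a much shorter group such as methyl, or to a chain ending in an amine or a carboxylic acid.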